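A few compounds are considered here, and "the series" means these few. Any claim that something is new, unique, unknown or untested is made for them only; others in the source may bear on it.

Of the compounds shown here, two have been measured in a functional assay on U-251 cells (Homo sapiens) for inhibition, read by MTT assay, with a stated time of 48 h; on this read-out lower numbers stand for stronger inhibition and higher numbers for weaker inhibition. Compound 1 `C#CCN(C)CCCOc1cc(NCc2ccc(/C=C/C(=O)NO)cc2)ccc1Cl` gives 990 nM, and compound 2 `C#CCN(C)CCCOc1cc(NC(=O)CCCCCCCCC(=O)NO)ccc1Cl` gives 16200 nM. Compound 2 thus holds the higher of the two numbers, and its gap to compound 1 lies beyond the scatter. Compound 3 `C#CCN(C)CCCOc1cc(NC(=O)CCCCCCCC(=O)NO)ccc1Cl` differs from compound 2 in one place: hydroxycarbamoyl in place of (hydroxycarbamoyl)methyl on a saturated chain carbon, seven bonds along the chain from a carbonyl carbon. For the measured compounds named here, no measured pair shows what such a change does in this assay, so only a small move toward a lower number is expected, perhaps none beyond the scatter. The expected change, estimated from the value of compound 2 and the structural difference alone, is a 1.8-fold lower number from compound 2 to compound 3 (0.26 log units; within the scatter). Compound 3 is estimated at 9000 nM, with an expected range of 3500 nM to 22000 nM.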

Compound 3, half-maximal inhibitory concentration: 4780 nM
The estimate for compound 3 lay 1.9-fold (0.27 log units) above the measured number; the range from low to high includes it.
By their numbers in this assay, from the lowest: compound 1; then compound 3; then compound 2.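

In this assay, replacing (hydroxycarbamoyl)methyl with hydroxycarbamoyl on a saturated chain carbon, seven bonds along the chain from a carbonyl carbon, gives a 3.4-fold lower number from compound 2 to compound 3 (0.53 log units; beyond the scatter). For the compounds shown here, this is the first measured evidence that the read-out responds to a change at this position, and a swap of this small size is enough to move the number beyond the usual scatter. Nothing available explains why this change gives a lower number.

Because this rests on one pair, the compounds shown do not reveal whether the number would keep falling if the chain were cut further, or whether it would rise again. They also leave open what a carboxylic acid or a primary amide would do in place of hydroxycarbamoyl on this same saturated chain carbon.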